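Para substituent swap on the N-aryl ring: chloro to ethyl

The source may hold more compounds than are shown below. What is called first, only, known or untested is meant among the compounds shown, and "the series" means these compounds.

Measured so far in an assay on Sf9 cells for inhibition of protein deacetylase HDAC6 (Homo sapiens), read by fluorescence, with a stated time of 40 min, tested at 100 nM; a lower number here means less inhibition, a higher number more inhibition at the concentration tested (going by the name of the read-out):
- compound 1 `COc1ccc(-n2nc(-c3ccccc3)nc2CNc2ccc(C(=O)NO)cc2)cc1`: 63.4%
- compound 2 `Cc1cccc(-n2nc(-c3ccccc3)nc2CNc2ccc(C(=O)NO)cc2)c1`: 66%
- compound 3 `O=C(NO)c1ccc(NCc2nc(-c3ccccc3)nn2-c2ccc(Cl)cc2)cc1`: 55.4%

Compound 3 gives the lowest of the three numbers in this assay. Its gap to compound 1 is within the scatter, a number 8 percentage points lower from compound 1 to compound 3 (within the scatter), while its gap to compound 2 is beyond it, a number 10.6 percentage points lower from compound 2 to compound 3 (beyond the scatter); the two substituted aryl rings on the aromatic nitrogen thus sit close together, with the chloro-bearing ring alone drawing a modest drop.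

Compound 4 `CCc1ccc(-n2nc(-c3ccccc3)nc2CNc2ccc(C(=O)NO)cc2)cc1` keeps the whole shared core and changes only the substituent on the N-aryl ring: ethyl in place of chloro on an aromatic carbon. Among the compounds with values here, no measured step puts an ethyl group on that ring, so the bearing steps are indirect. The step of a number 8 percentage points lower from compound 1 to compound 3 (within the scatter) shows that exchanging the para substituent moves the read-out only within the scatter, and a number 2.6 percentage points higher from compound 1 to compound 2 (within the scatter) shows a methyl-bearing ring landing near the methoxy-bearing one. Taken together, removing the chloro and adding a two-carbon group is expected to recover a few points, a step of a number 6.6 percentage points higher from compound 3 to compound 4 (within the scatter) that would not clear the scatter on its own.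

Compound 4 is therefore estimated to give 62%, within the range 50% to 74% in this assay.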

Compound 4, a percentage reported as inhibition, at one concentration (the size of the read-out at that concentration, not a potency): 38.3%
Estimate against measurement, compound 4: 23.7 percentage points above, and the stated range ends above it.
By their numbers in this assay, from the lowest: compound 4; then compounds 3, 1 and 2 (each within the scatter of the next, the first and the last beyond it).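

In this assay the substituent on the N-aryl ring matters more than the first three compounds suggested: exchanging chloro for ethyl gives a number 17.1 percentage points lower from compound 3 to compound 4 (beyond the scatter), and the distance from the other two rings is larger still, with a number 25.1 percentage points lower from compound 1 to compound 4 (beyond the scatter) and a number 27.7 percentage points lower from compound 2 to compound 4 (beyond the scatter). All three steps lie beyond the scatter, so compound 4 is the lowest of the four, and this position, where the 4-methoxyphenyl and 4-chlorophenyl rings stayed within the scatter of each other, does not treat every substituent alike. No measurement at hand gives a cause for this drop.

From the compounds shown here alone, it remains open whether the drop is particular to ethyl or continues with a longer chain such as propyl, and how a 4-methylphenyl ring would compare with both the 4-ethylphenyl ring and the 3-methylphenyl ring of compound 2. An amine or a carboxylic acid at the same place is equally open, and since every reading comes from a single concentration, the potency of these compounds also remains undefined.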